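Series notes: from compound 2 to compound 3

The compounds below may be only part of what the source reports. "The series", "measured", "known", "first", "only" and "open" are said of these compounds alone.

Measured so far:
compound 1 `COc1cc(C)nc2n/c(=N/C(=O)c3c(-c4ccc(Cl)cc4Cl)noc3C)sn12` — 80.6%
compound 2 `COc1cc(SC)nc(NC(=S)NC(=O)c2c(-c3ccc(Cl)cc3Cl)noc2C)n1` — 55.6%

In a functional assay on the whole organism for inhibition, with Digitaria ciliaris as the target, with a stated time of 72 h, tested at 100 mg/L (a higher number here means more inhibition of growth at the concentration tested, a lower number less inhibition of growth), compound 1 gives 80.6%. In this assay compound 2 gives 55.6%. Going by the values given here, compound 2 stands lowest of the two numbers; its only neighbour, compound 1, lies higher by a margin beyond the scatter. Among the compounds with values here, compound 1 and compound 2 differ in more than one place, so no single step connects them, and the two values show only that compound 2 is the weaker of the pair.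

Compound 3 `Cc1cc(C)nc(NC(=S)NC(=O)c2c(-c3ccc(Cl)cc3Cl)noc2C)n1` remains to be measured in this assay. Relative to compound 2 the change is 4,6-dimethylpyrimidin-2-yl in place of 4-methoxy-6-(methylsulfanyl)pyrimidin-2-yl on an amide-type nitrogen, in words 4,6-dimethylpyrimidin-2-yl in place of 4-methoxy-6-(methylsulfanyl)pyrimidin-2-yl on an amide-type nitrogen. Within the data shown here, no step between measured compounds covers this change, so there is no measured guide to its size or direction. Compound 3 is expected to show a step of a number 0.6 percentage points lower from compound 2 to compound 3 (within the scatter) from compound 2, that is, none beyond the scatter. Compound 3 is therefore estimated at 55%, with a range from 35% to 75%.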

Compound 3, percent growth inhibition at one concentration: 61.4%
The estimate for compound 3 lay 6.4 percentage points below the measured number, and the stated range covers the measured number.
By their numbers in this assay, from the lowest: compounds 2 and 3 (each within the scatter of the next); then compound 1.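

In this assay the series now has its first step that changes one place only, on an amide-type nitrogen whose other neighbour is the thiocarbonyl carbon: 4,6-dimethylpyrimidin-2-yl in place of 4-methoxy-6-(methylsulfanyl)pyrimidin-2-yl gives a number 5.8 percentage points higher from compound 2 to compound 3 (within the scatter) and so leaves the read-out unchanged within the usual variation. At this place, then, a group with 8 heavy atoms and 2 hydrogen-bond acceptors reads the same as one with 10 heavy atoms and 4 hydrogen-bond acceptors, so neither the methoxy nor the methylsulfanyl group is needed to hold growth inhibition at this level in the thiourea-linked compounds shown. No measurement is available that would explain this result.

Going by these compounds alone, open is whether other groups on the pyrimidin-2-yl ring, such as a dimethylamino group, a chlorine atom or a longer chain such as butoxy, would move the read-out beyond the usual variation, since the single step here covers only methyl, methoxy and methylsulfanyl. Within the data shown here, also open is whether the same exchange would read alike on the core of compound 1, which no single step yet connects to compound 2 or compound 3.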